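Replacing the dimethylphenyl group of compound 3 with hydroxyphenyl

The source may hold more compounds than are shown below. What is called first, only, known or untested is meant among the compounds shown, and "the series" means these compounds.

Measured so far in a functional assay on MCF7 cells (Homo sapiens) for antiproliferative activity, read by MTT assay, with a stated time of 72 h; a lower number here means a stronger inhibitor, a higher number a weaker inhibitor
compound 1 `COc1ccc(-c2ccc3ncn(-c4cc(OC)c(OC)c(OC)c4)c3c2)cc1F` gives 520 nM
compound 2 `COc1cc(-n2cnc3ccc(-c4cccc(F)c4)cc32)cc(OC)c1OC` gives 2350 nM
compound 3 `COc1cc(-n2cnc3ccc(-c4cccc(C)c4C)cc32)cc(OC)c1OC` gives 2150 nM

Compound 3 stands level with compound 2 (a 1.1-fold lower number from compound 2 to compound 3 (0.04 log units; within the scatter)) and well above compound 1 (a 4.1-fold higher number from compound 1 to compound 3 (0.62 log units; beyond the scatter)). Compound 4 `COc1cc(-n2cnc3ccc(-c4ccc(O)cc4)cc32)cc(OC)c1OC` has 4-hydroxyphenyl in place of 2,3-dimethylphenyl on an aromatic carbon. Only compound 1 carries oxygen on this outer ring, and losing its methoxy gave a modest rise (a 4.5-fold higher number from compound 1 to compound 2 (0.66 log units; beyond the scatter)). Hydroxy is not methoxy, so this guide is only partial, but a modest fall in this assay is expected (a 2.4-fold lower number from compound 3 to compound 4 (0.38 log units; beyond the scatter)). For compound 4 the estimate is 900 nM, within a range of 300 nM to 2600 nM.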

Compound 4, half-maximal inhibitory concentration: 4160 nM
Beside the measured number, compound 4's estimate is 4.6-fold (0.66 log units) below it; the whole stated range lies below it.
By their numbers in this assay, from the lowest: compound 1; then compounds 3, 2 and 4 (each within the scatter of the next).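

In this assay, a hydroxy group on the outer ring does not separate compound 4 from the oxygen-free compounds: a 1.9-fold higher number from compound 3 to compound 4 (0.29 log units; within the scatter) and a 1.8-fold higher number from compound 2 to compound 4 (0.25 log units; within the scatter) both stay within the scatter. Compound 1 stays apart, as an 8.0-fold higher number from compound 1 to compound 4 (0.90 log units; beyond the scatter) shows, so oxygen on this ring does not by itself give the number of compound 1. No measurement available here explains this result. Still open, on these data alone, is how an amine or a carboxylic acid would behave on this ring, and whether 4-methoxyphenyl, without the fluorine of compound 1, would stand nearer compound 1 or compound 4.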